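Cytotoxicity notes: replacing the 4-nitrophenyl group of compound 1

A few compounds are considered here, and "the series" means these few. Any claim that something is new, unique, unknown or untested is made for them only; others in the source may bear on it.

Measured in an ADME assay on L6 cells (Rattus norvegicus) for cytotoxicity, read by fluorescence and resazurin assay, with a stated time of 72 h; on this read-out higher numbers stand for lower toxicity in this test and lower numbers for higher toxicity in this test:
- compound 1 `O=[N+]([O-])c1ccc(-c2c[nH]cc2C(c2ccc(Cl)cc2Cl)n2ccnc2)cc1`: 16900 nM
- compound 2 `Clc1ccc(C(c2c[nH]cc2-c2ccc(-c3ccncc3)cc2)n2ccnc2)c(Cl)c1`: 15500 nM

Going by the values given here, with only these two values, compound 1 holds no separate place, since its one neighbour lies within the scatter: a 1.1-fold lower number from compound 1 to compound 2 (0.04 log units; within the scatter). Still to be measured is compound 3 `Clc1ccc(-c2c[nH]cc2C(c2ccc(Cl)cc2Cl)n2ccnc2)c(Cl)c1`, which carries 2,4-dichlorophenyl in place of 4-nitrophenyl on an aromatic carbon. Among the compounds with values here, the single measured step also alters the 4-nitrophenyl group, though it exchanges only the nitro for pyridin-4-yl, so it offers limited guidance. Within the data shown here, no compound with 2,4-dichlorophenyl at this place has a measured value yet. In this assay, no step beyond the scatter is therefore expected, although the uncertainty is wide. The expected step is a 1.3-fold lower number from compound 1 to compound 3 (0.11 log units; within the scatter). The estimate for compound 3 is 13000 nM, with an expected range from 4500 nM to 36000 nM.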

Compound 3, half-maximal cytotoxic concentration: 9860 nM
For compound 3 the middle estimate is 1.3-fold (0.12 log units) above the measured one, within the range that was stated.
By their numbers in this assay, from the lowest: compounds 3, 2 and 1 (each within the scatter of the next).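

In this assay, this aromatic carbon of the five-membered ring now has a result for a full exchange of the aryl group, not only of its nitro: 2,4-dichlorophenyl in place of 4-nitrophenyl gives a 1.7-fold lower number from compound 1 to compound 3 (0.23 log units; within the scatter) and so stays as close to compound 1 as the scatter can resolve. The group that leaves carries 2 hydrogen-bond acceptors and the group that enters carries 0, so in this test the nitro and its acceptors are not required to keep the number within the scatter of compound 1. No measurement available here accounts for this result.

The compounds shown leave open whether an unsubstituted phenyl at this place would also stay within the scatter of compound 1. They also leave open whether a phenyl carrying an amine or a carboxylic acid would do so.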